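Quinolin-8-yl Replaces Dichlorophenyl on the Piperazine Nitrogen

A few compounds are considered here, and "the series" means these few. Any claim that something is new, unique, unknown or untested is made for them only; others in the source may bear on it.

Compound 1 `O=C1c2ccccc2S(=O)(=O)N1CCCCCCN1CCN(c2ccc(Cl)c(Cl)c2)CC1` was tested in an ADME assay on HEK293 cells for displacement of a labelled ligand from 5-hydroxytryptamine receptor 7 (Homo sapiens), read by radioligand binding, with a stated time of 1 h (on this read-out higher numbers stand for weaker inhibition and lower numbers for stronger inhibition), where compound 1 gives 258 nM. This is the highest number of the three measured compounds. Compound 2 `O=C1c2ccccc2S(=O)(=O)N1CCCCCCN1CCN(c2ccccc2C(F)(F)F)CC1` gives 195 nM, a change of a 1.3-fold lower number from compound 1 to compound 2 (0.12 log units; within the scatter), and compound 3 `O=C1c2ccccc2S(=O)(=O)N1CCCCCCN1CCN(c2cccc(C(F)(F)F)c2)CC1` gives 58 nM, a change of a 4.4-fold lower number from compound 1 to compound 3 (0.65 log units; beyond the scatter). Between the two trifluoromethyl analogues the step is a 3.4-fold lower number from compound 2 to compound 3 (0.53 log units; beyond the scatter).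

Compound 4 `O=C1c2ccccc2S(=O)(=O)N1CCCCCCN1CCN(c2cccc3cccnc23)CC1` has not yet been measured. It differs from compound 1 in one place: quinolin-8-yl in place of 3,4-dichlorophenyl on an amine nitrogen in a ring. For the measured compounds named here, none of the measured steps exchanges the aryl group for a quinolin-8-yl, so no step bears on it directly. What the measured steps do show is that replacing the 3,4-dichlorophenyl on the amine nitrogen in the ring moved the number from compound 1 either within the scatter, a 1.3-fold lower number from compound 1 to compound 2 (0.12 log units; within the scatter), or modestly lower, a 4.4-fold lower number from compound 1 to compound 3 (0.65 log units; beyond the scatter). On that basis the step to compound 4 is expected to be modest and toward a lower number, though a change within the scatter cannot be ruled out. Compound 4 is therefore estimated at 120 nM, within a range of 35 nM to 400 nM. This estimate corresponds to an expected step of a 2.2-fold lower number from compound 1 to compound 4 (0.33 log units; beyond the scatter).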

Compound 4, inhibition constant: 21 nM
Estimate against measurement, compound 4: 5.7-fold (0.76 log units) above; measured number below the stated range.
By their numbers in this assay, from the lowest: compound 4; then compound 3; then compounds 2 and 1 (each within the scatter of the next).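

In this assay, for the compounds shown here, this position on the amine nitrogen in the ring proves able to carry a much larger change than the two trifluoromethyl analogues had suggested, with quinolin-8-yl in place of 3,4-dichlorophenyl giving a large step (a 12-fold lower number from compound 1 to compound 4 (1.09 log units; beyond the scatter)) where the earlier steps from compound 1 were modest at most. The gain also extends past both trifluoromethyl-substituted phenyl groups (a 2.8-fold lower number from compound 3 to compound 4 (0.44 log units; beyond the scatter); a 9.3-fold lower number from compound 2 to compound 4 (0.97 log units; beyond the scatter)), so compound 4 has the lowest number of the four, with its steps to all the others beyond the scatter. The change adds a six-membered aromatic ring with 1 hetero atom and a hydrogen-bond acceptor to the group on this nitrogen, but no measurement shown here accounts for the gain.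

The compounds shown leave open whether the gain follows the ring nitrogen of the quinolin-8-yl or its second aromatic ring, which a naphthalen-1-yl group on the same amine nitrogen would separate. Going by these compounds alone, they also leave open whether quinolin-8-yl keeps its place in this order on a shorter or longer chain than the one all four compounds share.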